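A fourth analogue for the HepG2 antiproliferative screen

A few compounds are considered here, and "the series" means these few. Any claim that something is new, unique, unknown or untested is made for them only; others in the source may bear on it.

Compound 1 `Cc1cccc(-n2nncc2CN2C(=O)C3(C(C#N)=C(N)Oc4c3c3nc5ccccc5nc3c3ccccc43)c3ccccc32)c1` — in a functional assay on HepG2 cells (Homo sapiens) for antiproliferative activity, read by MTT assay, with a stated time of 48 h (on this read-out lower numbers stand for stronger inhibition and higher numbers for weaker inhibition), compound 1 gives > 50000 nM, a limit of the assay.
Compound 2 `Cc1ccc(Cl)cc1-n1nncc1CN1C(=O)C2(C(C#N)=C(N)Oc3c2c2nc4ccccc4nc2c2ccccc32)c2ccccc21` — in this assay compound 2 gives > 50000 nM, a limit of the assay.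
Compound 3 `N#CC1=C(N)Oc2c(N)cc3nc4ccccc4nc3c2C12C(=O)N(Cc1cnnn1-c1ccc(F)cc1)c1ccccc12` — in this assay compound 3 gives > 50000 nM, a limit of the assay.

Three compounds share one core and differ in the aryl group on an aromatic nitrogen of the triazole ring and in one substituent on the core. None of them gives a number in this assay: all three sit where the limit of > 50000 nM in this assay, at which 3 of the 3 values shown sit, stands. Within the data shown here, the only one-place step, a step that the two limits leave unreadable from compound 1 to compound 2, therefore cannot be read, and nothing measured says whether an aryl change on that nitrogen moves the read-out at all.

Compound 4 `Cc1ccc(-n2nncc2CN2C(=O)C3(C(C#N)=C(N)Oc4c(N)cc5nc6ccccc6nc5c43)c3ccccc32)cc1C` carries the amino-bearing core of compound 3 and differs from it by 3,4-dimethylphenyl in place of 4-fluorophenyl on an aromatic nitrogen. Among the measured compounds shown here, no measured step bears readably on this change. Since compound 3 rests on the limit > 50000 nM, compound 4 is expected to do the same, with a step that the limit leaves unreadable from compound 3 to compound 4 that cannot be separated from the scatter; the estimate for compound 4 is 60000 nM, in the range 20000 nM to 200000 nM.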

Compound 4, half-maximal inhibitory concentration: > 50000 nM
Compound 4: only a limit was reported (the forecaster's own chance of this, stated with the estimate: 85%); the middle value does not contradict the limit.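

Compound 3 and compound 4 both give only a limit of the assay, so the step between them cannot be read: the limit of > 50000 nM in this assay, at which 4 of the 4 values shown sit.

The compounds shown leave open whether any aryl group on that aromatic nitrogen moves the read-out in this assay at all.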